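The source may hold more compounds than are shown below. What is called first, only, known or untested is meant among the compounds shown, and "the series" means these compounds.

Working notes on a small set built around one shared core. Compound 1 `O=C(O)C1=Cc2ccccc2OC1(OCc1cc(-c2ccc([N+](=O)[O-])cc2)no1)C(F)(F)F` and compound 3 `CCOC(=O)C1=Cc2ccccc2OC1(OCc1cc(-c2ccc(C)cc2)no1)C(F)(F)F` differ from compound 2 `CCCCCCCCn1cc(COC2(C(F)(F)F)Oc3ccccc3C=C2C(=O)OCC)nn1` in the ester group and in the ether-linked side chain; compound 4 `CCOC(=O)C1=Cc2ccccc2OC1(OCc1cn(CC(=O)Nc2cccc(Cl)c2)nn1)C(F)(F)F` is the one not yet measured.

In a functional assay on MCF7 cells (Homo sapiens) for inhibition, read by MTT assay, with a stated time of 24 h (on this read-out lower numbers stand for stronger inhibition and higher numbers for weaker inhibition), compound 1 gives only a limit, > 150000 nM. In this assay compound 3 also reaches only a limit, > 150000 nM. Compound 2 stands at the same limit in this assay, > 150000 nM. All three values shown are therefore limits rather than numbers, which is what the limit of > 150000 nM in this assay, at which 3 of the 3 values shown sit, records; compound 2 can be placed no more precisely than that.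

The change from compound 2 to compound 4 is (3-chlorophenyl)carbamoyl in place of heptyl on a saturated chain carbon bound to an aromatic nitrogen. Among the measured compounds shown here, no step between measured compounds exists here, so the size of the effect of such a change in this assay cannot be read from the data, and three limits give no direction either. The expectation is that compound 4 stays at the limit: an estimated 150000 nM, within 60000 nM to 400000 nM. That estimate means an expected step of a number no higher from compound 2 to compound 4 (the limit leaves the size open), none beyond the scatter.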

Compound 4, half-maximal inhibitory concentration: 11600 nM
Compound 4: the middle estimate sits 13-fold (1.11 log units) above what was measured, outside the stated range (below it).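

In this assay, the place on a saturated chain carbon bound to an aromatic nitrogen proves able to move the read-out: (3-chlorophenyl)carbamoyl in place of heptyl gives an at least 12-fold lower number from compound 2 to compound 4 (1.11 log units; beyond the scatter). On these data alone, the full size of this change remains unknown, as compound 2 gives only a limit. Among the compounds shown, only compound 4 gives a number rather than a limit: the limit of > 150000 nM in this assay, at which 3 of the 4 values shown sit.

The compounds shown do not separate the contribution of the carbamoyl from that of the 3-chlorophenyl ring, nor that of the added atoms from the loss of heptyl. As far as these compounds go, whether a phenylcarbamoyl without chlorine or a simple acetamide at this place would give a number in this assay remains open.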